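The source may hold more compounds than are shown below. What is called first, only, known or untested is meant among the compounds shown, and "the series" means these compounds.

Measured compounds:
Compound 1 `Cc1c(N(C)C)nc(CCCCCCCCCCO)c(O)c1C` — 36%
Compound 2 `CCCCCCCCCCCCCCCCCCCc1c(C)c(N(C)C)nc(C)c1O` — 42%

In a functional assay on cells (Lymphocyte, Homo sapiens) for inhibition, read by flow cytometry, using a membrane potential dye, with a stated time of 16 h, tested at 250 nM (on this read-out higher numbers stand for a stronger effect at the one concentration tested and lower numbers for a weaker effect), compound 1 gives 36%, the lower of the two numbers shown, while compound 2 gives 42%; the gap between them lies within the scatter, so neither stands apart. Compound 3 `CCCCCCCCCCc1nc(N(C)C)c(C)c(C)c1O` differs from compound 1 in one place: hydrogen in place of hydroxy on a saturated chain carbon, ten or more bonds along the chain from an aromatic carbon. Within the data shown here, with no measured step of this kind available, the expected change in this assay is a number 4 percentage points higher from compound 1 to compound 3 (within the scatter), which is not beyond the scatter. Compound 3 is therefore estimated at 40%, with a range from 25% to 55%.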

Compound 3, a percentage reported as activity, at one concentration (the size of the read-out at that concentration, not a potency): 82%
Estimate against measurement, compound 3: 42 percentage points below; measured number outside the range, above it.
By their numbers in this assay, from the lowest: compounds 1 and 2 (each within the scatter of the next); then compound 3.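

In this assay, hydrogen in place of hydroxy on a saturated chain carbon, ten or more bonds along the chain from an aromatic carbon, gives a number 46 percentage points higher from compound 1 to compound 3 (beyond the scatter), a large step from one change. The earlier pair, within the scatter of each other, gave no sign that this far along the chain a single hydroxy could matter so much. Nothing measured here bears on the reason for this step.

Going by these compounds, it stays open how an amine, a carboxylic acid or a methyl ether at this place would compare with compound 1 and compound 3. On these data alone, the effect of a shorter or longer chain on the core of compound 3 also stays open.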